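The compounds below may be only part of what the source reports. "The series", "measured", "known", "first", "only" and "open" are said of these compounds alone.

Among the measured compounds shown here, only two compounds with this shared core have numbers so far. For the measured compounds named here, in a functional assay on PC-3 cells (Homo sapiens) for cytotoxicity (on this read-out higher numbers stand for weaker inhibition and lower numbers for stronger inhibition), compound 1 `C[C@@H]1O[C@@H](n2c3ccccc3c3c4c(c5c6ccccc6ccc5c32)C(=O)NC4=O)[C@H](O)[C@H](O)[C@H]1O` gives 2700 nM and compound 2 `O=C1NC(=O)c2c1c1c3ccccc3ccc1c1c2c2ccccc2n1[C@H]1OC[C@@H](O)[C@@H](O)[C@H]1O` gives 2100 nM, so compound 2 stands within the scatter of the only other measured value. The unmeasured compound 3 `O=C1NC(=O)c2c1c1c3ccccc3ccc1c1c2c2ccccc2n1[C@@H]1O[C@H](CO)[C@@H](O)[C@H](O)[C@H]1O` keeps the core and changes a single group: a group of 11 heavy atoms (6 carbon, 5 oxygen; one six-membered non-aromatic ring with 1 hetero atom) in place of a group of 9 heavy atoms (5 carbon, 4 oxygen; one six-membered non-aromatic ring with 1 hetero atom), on an aromatic nitrogen. The entering group is 3,4,5-trihydroxy-6-(hydroxymethyl)oxan-2-yl, and it sits on an aromatic nitrogen of a five-membered aromatic ring with 1 nitrogen. Going by the values given here, one measured step bears on this change, because it swaps groups at the same aromatic nitrogen: a 1.3-fold lower number from compound 1 to compound 2 (0.11 log units; within the scatter). That step did not leave the scatter. Among the compounds with values here, it is thin evidence, however, and no measured compound carries the entering group. No step beyond the scatter is therefore expected in this assay, although the uncertainty remains wide. The expected step is a 1.1-fold higher number from compound 2 to compound 3 (0.06 log units; within the scatter). Compound 3 is estimated at 2400 nM, with an expected range from 800 nM to 7000 nM.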

Compound 3, half-maximal inhibitory concentration: 2300 nM
Estimate against measurement, compound 3: 1.0-fold (0.02 log units) above; low and high end bracket the measured number.
By their numbers in this assay, from the lowest: compounds 2, 3 and 1 (each within the scatter of the next).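

The new number extends the comparison at this aromatic nitrogen to a third group: in this assay, the change to 3,4,5-trihydroxy-6-(hydroxymethyl)oxan-2-yl gives a 1.1-fold higher number from compound 2 to compound 3 (0.04 log units; within the scatter), and exchanging 3,4,5-trihydroxy-6-methyloxan-2-yl for the same group gives a 1.2-fold lower number from compound 1 to compound 3 (0.07 log units; within the scatter). With every step among compounds 1, 2 and 3 now inside the scatter, this read-out does not separate the three groups, even though the group in compound 3 has more heavy atoms, hydrogen-bond donors and acceptors than the group in compound 2. Nothing available explains why the three numbers lie so close together.

All three compounds carry a six-membered non-aromatic ring with one hetero atom on this nitrogen, so the result says nothing about a group without that ring, such as a simple ethyl chain or a longer chain ending in an amine. It also leaves open whether a carboxylic acid in place of the hydroxymethyl on the ring would stay within the scatter, or whether a change elsewhere on the shared core would move the number further.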